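The source may report more compounds than this note shows. Statements on the series, on what has been measured and on what is new or still open speak of the compounds shown alone.

Measured so far:
Compound 1 `O=C1C=C(NCc2ccccc2)C(=O)c2c1nc1n2[C@H]2OC[C@@H](O)[C@H]2OC1`. In a functional assay on ECa-109 cells for inhibition, with ECa-109 cell line (Homo sapiens) as the target, read by sulforhodamine B assay (on this read-out lower numbers stand for stronger inhibition and higher numbers for weaker inhibition), compound 1 gives > 8000 nM, which is a limit of the assay and not a number.
Compound 2 `CCc1ccc(NC2=CC(=O)c3nc4n(c3C2=O)[C@H]2OC[C@@H](O)[C@H]2OC4)cc1`. In this assay compound 2 gives 3080 nM.
Compound 3 `O=C1C(N2CCCC2)=CC(=O)c2c1nc1n2[C@H]2OC[C@@H](O)[C@H]2OC1`. In this assay compound 3 gives > 16000 nM, again a limit of the assay and not a number.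

Among the measured compounds shown here, compound 2 therefore holds the only number; the other two values are limits. For the measured compounds named here, the single measured step, an at least 2.5-fold lower number from compound 1 to compound 2 (0.41 log units; beyond the scatter), came with 4-ethylphenyl in place of benzyl on an amine nitrogen, a change of the whole group on that nitrogen.

Compound 4 `CCCc1ccc(NC2=CC(=O)c3nc4n(c3C2=O)[C@H]2OC[C@@H](O)[C@H]2OC4)cc1` differs from compound 2 by methyl in place of hydrogen on a saturated chain carbon, two bonds along the chain from an aromatic carbon. Going by the values given here, no measured step concerns a change of this kind: the step from compound 1 to compound 2 exchanges the entire substituent on the amine nitrogen, and compound 3 carries a ring amine in place of that nitrogen, with only a limit recorded. Among the compounds with values here, nothing measured so far speaks to methyl in place of hydrogen on a saturated chain carbon. The expectation is therefore no step beyond the scatter in this assay. Compound 4 is estimated at 3000 nM, within 1200 nM to 8000 nM, which means an expected 1.0-fold lower number from compound 2 to compound 4 (0.01 log units; within the scatter).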

Compound 4, half-maximal inhibitory concentration: > 4000 nM
Compound 4 gave a limit, no number; the forecaster's own chance of this, stated with the estimate: 10%; middle value at least 1.3-fold (0.12 log units) from the limit.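

Among the compounds shown here, this is the first reading on the chain of the 4-ethylphenyl group: in this assay, going from ethyl to propyl gives an at least 1.2-fold higher number from compound 2 to compound 4 (0.11 log units; that floor lies within the scatter), so this floor alone does not separate the two compounds. For compound 4 the reading is a limit of the assay and not a number: the limit of > 4000 nM in this assay, at which 1 of the 4 values shown sits. For the compounds shown here, compound 2 therefore remains the only compound with a number, and the steps linking compound 4 to compound 1 cannot be read, as both values are limits.

From the compounds shown here alone, how far the true value of compound 4 lies from its limit remains open, and so does the real size of the change from ethyl to propyl. Also open, going by these compounds, is whether phenyl, 4-methylphenyl, or a 4-substituent with a longer chain or one ending in a hydroxyl or an amine would give a lower number than compound 2.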